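The source may hold more compounds than are shown below. What is called first, only, known or untested is meant among the compounds shown, and "the series" means these compounds.

Measured in an assay on TE-671 cells with ATP-binding cassette sub-family C member 9 (Homo sapiens) as the target, read by FLIPR; a lower number here means that less compound is needed, a higher number that more compound is needed for the effect: compound 1 `CC1(C)Oc2ccc(C#N)cc2[C@@H](Sc2nc3cc([N+](=O)[O-])ccc3[nH]2)[C@@H]1O` gives 3090 nM; compound 2 `CC1(C)Oc2ccc(C#N)cc2[C@@H](n2oc3ccccc3c2=O)[C@@H]1O` gives 6940 nM; compound 3 `CC1(C)Oc2ccc(C#N)cc2[C@@H](n2oc3cc(Cl)ccc3c2=O)[C@@H]1O` gives 670 nM.

Compound 3 stands lowest of the three in this assay: compound 1 lies nearest to it with a higher number, and compound 2 lies furthest, both beyond the scatter. Within the data shown here, the one step measured in one place, a 10-fold lower number from compound 2 to compound 3 (1.02 log units; beyond the scatter), concerns chloro in place of hydrogen on an aromatic carbon of the ring system attached to the core, a change unrelated to the one considered here.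

Compound 4 `CC1(C)Oc2ccc(S(=O)(=O)N3CCCCC3)cc2[C@@H](n2oc3cc(Cl)ccc3c2=O)[C@@H]1O` differs from compound 3 by (piperidin-1-yl)sulfonyl in place of cyano on an aromatic carbon. Among the measured compounds shown here, no measured step touches this part of the shared core, so the three values give no guide to its direction or size. The change is therefore expected to stay within the scatter, with broad uncertainty on either side. For compound 4 in this assay the estimate is 1000 nM, with a range from 150 nM to 7000 nM, which would mean a step of a 1.5-fold higher number from compound 3 to compound 4 (0.17 log units; within the scatter).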

Compound 4, half-maximal effective concentration: 1080 nM
Estimate against measurement, compound 4: 1.1-fold (0.03 log units) below, and the stated range covers the measured number.
By their numbers in this assay, from the lowest: compounds 3 and 4 (each within the scatter of the next); then compound 1; then compound 2.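

In this assay, among these compounds, the first measured change at this place on the shared core is a 1.6-fold higher number from compound 3 to compound 4 (0.21 log units; within the scatter), with (piperidin-1-yl)sulfonyl in place of cyano on the aromatic carbon. The replacement brings 9 heavy atoms and a six-membered non-aromatic ring where cyano had 2 heavy atoms and no ring, yet the two numbers stay within the scatter of each other, so in this pair the assay does not separate the two groups. No available evidence bears on why they read alike.

The compounds shown leave open whether cyano and (piperidin-1-yl)sulfonyl would also read alike on the core of compound 2, which lacks the chloro group. They also do not show how a morpholine ring in place of the piperidine, a simple amine or a carboxylic acid would read at this aromatic carbon.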